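The source may report more compounds than this note shows. Statements on the series, on what has been measured and on what is new or still open speak of the compounds shown alone.

Measured compounds:
Compound 1 `CN(C)C(=S)SC(=S)N1CCCC1`: 3090000 nM
Compound 2 `CC1CCCN(C(=S)SC(=S)N(C)C)C1`: 2900000 nM
Compound 3 `CCOC(=O)N1CCN(C(=S)SC(=S)N(C)C)CC1`: 530000 nM

In an ADME assay on HeLa cells (Homo sapiens) for cytotoxicity, read by MTT assay, with a stated time of 24 h (on this read-out higher numbers stand for weaker inhibition and lower numbers for stronger inhibition), compound 3 gives 530000 nM, the lowest of the three numbers; its gaps to compound 2 and to compound 1 both lie beyond the usual scatter. Compound 4 `CSC(=S)N1CCN(C(=S)SC(=S)N(C)C)CC1` has not been measured in this assay. It differs from compound 3 in one place: a group of 4 heavy atoms (2 carbon, 2 sulfur; no ring) in place of a group of 5 heavy atoms (3 carbon, 2 oxygen; no ring), on an amine nitrogen in a ring. Among the compounds with values here, no measured pair shows this change, so the direction and size of the step are open. The expectation is that compound 4 stays close to compound 3, with a step of a 1.5-fold lower number from compound 3 to compound 4 (0.18 log units; within the scatter) that may fall within the scatter. Compound 4 is estimated at 350000 nM, with a range from 70000 nM to 1800000 nM.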

Compound 4, half-maximal inhibitory concentration: > 5000000 nM
Compound 4 ended at the assay's limit; the forecaster's own chance of this, stated with the estimate: 5%; middle value at least 14-fold (1.15 log units) from the limit.
By their numbers in this assay, from the lowest: compound 3; then compounds 2 and 1 (each within the scatter of the next). At a limit, above all of these: compound 4.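

The earlier compounds shown here offered no comparison of a single change, and this pair gives the first: in this assay, replacing ethoxycarbonyl on the amine nitrogen in the ring gives an at least 9.4-fold higher number from compound 3 to compound 4 (0.97 log units; beyond the scatter). The group on this nitrogen therefore matters to the read-out, even though the two groups are close in heavy-atom count. Compound 4 sits at a limit of the assay, and it is the only compound here that does: the limit of > 5000000 nM in this assay, at which 1 of the 4 values shown sits.

One pair cannot show which atoms of the two groups carry the step. On these data alone, how an acetyl group or a longer alkyl chain on this nitrogen would read stays open.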